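The source may report more compounds than this note shows. Statements on the series, on what has been measured and on what is new or still open speak of the compounds shown alone.

Working notes on the series. Compound 1 `COc1cc(C[C@@H](C)[C@@H](C)Cc2ccc(OC(=O)c3cnccn3)c(OC)c2)ccc1OC(=O)c1cnccn1` is the closest relative of the pair; in an ADME assay on Vero cells (Chlorocebus sabaeus) for cytotoxicity, read by trypan blue exclusion, with a stated time of 24 h (a higher number here means a weaker inhibitor, a lower number a stronger inhibitor), compound 1 gives "not determined" (no result reported), so it contributes no number. For the measured compounds named here, compound 2 `COc1cc(C[C@@H](C)[C@@H](C)Cc2ccc(OC(=O)c3cnccn3)c(OC)c2)ccc1O` is the only compound with a figure: in this assay compound 2 gives 43.3 ug/mL. On the numbers shown, compound 2 therefore stands alone as the single measured point, and no step between measured compounds can be drawn from it; compound 1 offers nothing to compare against.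

Compound 3 `COc1cc(C[C@@H](C)[C@@H](C)Cc2ccc(OC(=O)c3ccc(Br)cc3)c(OC)c2)ccc1O` is not yet measured. It differs from compound 2 in one place: 4-bromophenyl in place of pyrazin-2-yl on a carbonyl carbon. The remainder of the shared core is unchanged.

Going by the values given here, with no measured step available to calibrate this exchange, the expectation for compound 3 is cautious. The step from compound 2 is expected to be a 1.1-fold lower number from compound 2 to compound 3 (0.06 log units; within the scatter), which is not expected to lie clearly beyond the usual scatter in either direction, since nothing in the data shown argues for a shift. For compound 3 the estimate in this assay is 38 ug/mL, with a range from 15 ug/mL to 90 ug/mL.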

Compound 3, half-maximal inhibitory concentration: 112 ug/mL
Compound 3: middle estimate off by 2.9-fold (0.47 log units), on the low side; measured number outside the range, above it.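

In this assay, for the compounds shown here, the exchange of pyrazin-2-yl for 4-bromophenyl on a carbonyl carbon gives a 2.6-fold higher number from compound 2 to compound 3 (0.41 log units; beyond the scatter), which is the first measured step. This shows that the group at this position is not silent in this read-out: a change here alone moves the number beyond the scatter, although the step is modest and the direction is towards a weaker inhibitor with 4-bromophenyl in place. Nothing available explains this step.

The single step changes the ring atoms and adds the bromine together, so the compounds shown cannot separate the part played by each; an unsubstituted phenyl or a pyridin-2-yl on the same carbonyl carbon would be needed to divide the two. Going by these compounds, it also remains open whether the trend continues with other groups at this position, such as a 4-chlorophenyl, a 4-aminophenyl or a 4-carboxyphenyl, since one step gives a difference between two groups and not a trend across several.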